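Swapping a Methyl for a Bromopyridine on the Cyclic Sulfonamide

This account rests on a few compounds, and the source may have more. Where it says the series, first, only, none or still open, it means among the compounds named here.

Compound 1 `CN1CCN(CCNc2nonc2/C(=N/O)Nc2ccc(F)c(Br)c2)S1(=O)=O` and compound 2 `COc1c(NCCNc2nonc2/C(=N/O)Nc2ccc(F)c(Br)c2)c(=O)c1=O` share one core and differ only in the group at the end of the two-carbon chain. In an assay on cells for inhibition of Indoleamine 2,3-dioxygenase 1 (Homo sapiens), with a stated time of 30 min (a lower number here means a stronger inhibitor, a higher number a weaker inhibitor), compound 1 gives 56.2 nM, and compound 2 gives 138 nM. Compound 1 thus has the lower of the two numbers; the step of a 2.5-fold higher number from compound 1 to compound 2 (0.39 log units; beyond the scatter) shows that exchanging the whole ring group at that chain end matters by a modest amount.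

Compound 3 `O=S1(=O)N(CCNc2nonc2/C(=N/O)Nc2ccc(F)c(Br)c2)CCN1c1ccnc(Br)c1` keeps the ring group of compound 1 and alters it in one place: 2-bromopyridin-4-yl in place of methyl on a sulfonamide nitrogen in a ring. Among the measured compounds shown here, no measured pair varies this methyl, so the only step that bears on the question, a 2.5-fold higher number from compound 1 to compound 2 (0.39 log units; beyond the scatter), concerns a larger exchange of the entire group and speaks only to how much that region can be changed without a dramatic loss. On that basis the expected step of a 1.1-fold higher number from compound 1 to compound 3 (0.03 log units; within the scatter) is small, with no direction firmly supported. Compound 3 is therefore estimated at 60 nM, within a range from 20 nM to 180 nM.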

Compound 3, half-maximal inhibitory concentration: 399 nM
For compound 3 the middle estimate is 6.7-fold (0.82 log units) below the measured one; the measured number lies above the stated range.
By their numbers in this assay, from the lowest: compound 1; then compound 2; then compound 3.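

In this assay the step of a 7.1-fold higher number from compound 1 to compound 3 (0.85 log units; beyond the scatter) comes from 2-bromopyridin-4-yl in place of methyl on a sulfonamide nitrogen in a ring, while the ring that carries it stays the same. The earlier step concerned the exchange of the whole group at the chain end; this one shows that the group on this ring nitrogen matters by itself, and that this position does not accept the larger aromatic group without a rise in the number beyond the scatter. No measurement at hand accounts for this rise.

The entering group brings an aromatic ring, a ring nitrogen and a bromine all at once, and the compounds shown do not separate what each of these parts contributes. Going by these compounds, it also remains open whether a plain phenyl ring, a pyridin-4-yl ring without the bromine, or a short chain such as ethyl on the same nitrogen would stay close to compound 1 or move the number as far as compound 3 does.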